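A few compounds are considered here, and "the series" means these few. Any claim that something is new, unique, unknown or untested is made for them only; others in the source may bear on it.

The measured compounds and their values in a functional assay (aorta) with Rattus norvegicus as the target; on this read-out lower numbers stand for stronger inhibition and higher numbers for weaker inhibition:

Compound 1, `CCO/C(O)=C1\C(COCCn2cc(N)n(C)c2=O)=NC(C)=C(C(=O)OC)C1c1ccccc1Cl`, gives 25.1 nM in this assay.
Compound 2, `CCO/C(O)=C1\C(COCCn2ccnn2)=NC(C)=C(C(=O)OC)C1c1cccc(Cl)c1Cl`, gives 5.01 nM in this assay.
Compound 3, `CCO/C(O)=C1\C(COCCn2nncc2C(N)=O)=NC(C)=C(C(=O)OC)C1c1ccccc1Cl`, gives 100 nM in this assay.

Among these three, compound 1 stands second highest: compound 3 lies above it and compound 2 below it, each beyond the scatter. Compound 2 differs from compound 1 in two places, so its lower number cannot be tied to a single change.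

Compound 4, `CCO/C(O)=C1\C(COCCN2CC(=O)NC2=O)=NC(C)=C(C(=O)OC)C1c1ccccc1Cl`, has not yet been measured in this assay. It differs from compound 1 as follows: a group of 7 heavy atoms (3 carbon, 2 nitrogen, 2 oxygen; one five-membered non-aromatic ring with 2 hetero atoms) in place of a group of 8 heavy atoms (4 carbon, 3 nitrogen, 1 oxygen; one five-membered aromatic ring with 2 hetero atoms), on a saturated chain carbon, two bonds along the chain from an oxygen on a saturated carbon.

Among the compounds with values here, one measured step bears on this change, the one at the same place where an aromatic ring with more hetero atoms replaced the ring of compound 1: a 4.0-fold higher number from compound 1 to compound 3 (0.60 log units; beyond the scatter). In compound 4 the ring that enters is non-aromatic and carries fewer hydrogen-bond acceptors than the ring that leaves, so a weakening of similar size is expected rather than none. Compound 4 is therefore estimated to give 45 nM in this assay, within a range of 12 nM to 170 nM. This means an expected step of a 1.8-fold higher number from compound 1 to compound 4 (0.25 log units; within the scatter).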

Compound 4, half-maximal inhibitory concentration: 20 nM
Compound 4: the middle estimate sits 2.3-fold (0.35 log units) above what was measured; the range from low to high includes it.
By their numbers in this assay, from the lowest: compound 2; then compounds 4 and 1 (each within the scatter of the next); then compound 3.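

In this assay, the 2,4-dioxoimidazolidin-1-yl group on this saturated chain carbon, two bonds along the chain from an oxygen on a saturated carbon, stands level with the aromatic ring it replaces (a 1.3-fold lower number from compound 1 to compound 4 (0.10 log units; within the scatter)). A non-aromatic ring with fewer hydrogen-bond acceptors is therefore accepted at this place without a shift beyond the scatter, so a change of ring here need not raise the number. The direct comparison with 5-carbamoyl-1H-1,2,3-triazol-1-yl (a 5.0-fold lower number from compound 3 to compound 4 (0.70 log units; beyond the scatter)) ties the higher number of compound 3 to that group rather than to every replacement of the ring in compound 1, though no measurement here accounts for the difference between these groups.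

The compounds shown leave open whether a carboxylic acid, a simple amine or a longer chain at this place would stay within the same range. Going by these compounds, compound 2 differs from the others in more than one place, so its steps cannot be read, and whether 2,4-dioxoimidazolidin-1-yl would behave the same way alongside its second ring chlorine remains unknown.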